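The source may report more compounds than this note shows. Statements on the series, on what has been measured and on what is new or still open speak of the compounds shown alone.

Measured in a functional assay on NCI-H460 cells (Homo sapiens) for cytotoxicity, read by MTT assay, with a stated time of 3 days (on this read-out lower numbers stand for stronger inhibition and higher numbers for weaker inhibition), so far:
- Compound 1 `CCNc1nc(SCc2nc3ccccc3[nH]2)nc(-c2ccccc2)c1C#N` gives 2.87 nM
- Compound 2 `N#Cc1c(Nc2ccccn2)nc(SCc2nc3ccccc3[nH]2)nc1-c1ccccc1` gives 2.8 nM
- Compound 3 `N#Cc1c(NC(N)=O)nc(SCc2nc3ccccc3[nH]2)nc1-c1ccccc1` gives 14.7 nM

Compound 3 has the highest number of the three and is therefore the weakest so far. Pyridin-2-yl in place of ethyl gives a 1.0-fold lower number from compound 1 to compound 2 (0.01 log units; within the scatter) and so makes no real difference. Carbamoyl in place of ethyl gives a 5.1-fold higher number from compound 1 to compound 3 (0.71 log units; beyond the scatter) and is a modest loss. Carbamoyl in place of pyridin-2-yl gives a 5.3-fold higher number from compound 2 to compound 3 (0.72 log units; beyond the scatter) and is a loss of much the same size.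

The next compound is compound 4 `CN1CCN(c2nc(SCc3nc4ccccc4[nH]3)nc(-c3ccccc3)c2C#N)CC1`, with 4-methylpiperazin-1-yl in place of ureido on an aromatic carbon. The counted change is 4-methylpiperazin-1-yl in place of ureido on an aromatic carbon and it sits on the shared core. Among the compounds with values here, no measured compound carries this group, so the earlier steps are only a loose guide. Still, removing the ureido group of compound 3 should recover part of the loss seen in a 5.1-fold higher number from compound 1 to compound 3 (0.71 log units; beyond the scatter) and would move the number down, perhaps not all the way. The expected change is a 2.5-fold lower number from compound 3 to compound 4 (0.39 log units; beyond the scatter) and is only modest. For compound 4 the estimated value is 6 nM with an expected range from 1.5 nM to 25 nM in this assay for now.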

Compound 4, half-maximal inhibitory concentration: 2.84 nM
Compound 4: the middle estimate sits 2.1-fold (0.32 log units) above what was measured; measured number inside the range.
By their numbers in this assay, from the lowest: compounds 2, 4 and 1 (each within the scatter of the next); then compound 3.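

In this assay the position on the shared core that held ethylamino, (pyridin-2-yl)amino and ureido also accepts 4-methylpiperazin-1-yl, a six-membered non-aromatic ring that joins through a ring nitrogen carrying no hydrogen and has 0 hydrogen-bond donors. Putting this ring in place of ureido is a modest gain (a 5.2-fold lower number from compound 3 to compound 4 (0.71 log units; beyond the scatter)), yet it shows no real difference from the smaller (pyridin-2-yl)amino group (a 1.0-fold higher number from compound 2 to compound 4 (0.01 log units; within the scatter)) or from ethylamino (a 1.0-fold lower number from compound 1 to compound 4 (0.00 log units; within the scatter)), so a hydrogen on the attaching nitrogen is not needed for a number at this level, and among the four compounds only the ureido group of compound 3 stands apart. Nothing given here explains why ureido differs from the other groups at this position.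

On these data alone, it remains open whether the loss belongs to the carbonyl of ureido or to its terminal amino group, which an acetylamino group or a plain amino group could help to separate. As far as these compounds go, it is also open how far this tolerance extends, for example to morpholin-4-yl, to a piperazine without the methyl group, or to a group carrying a carboxylic acid.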